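Trimming the Sulfonyl Ring of Compound 2

This account rests on a few compounds, and the source may have more. Where it says the series, first, only, none or still open, it means among the compounds named here.

Measured in a functional assay on BXPC-3 cells (Homo sapiens) for inhibition, read by MTT assay, with a stated time of 7 days; on this read-out higher numbers stand for weaker inhibition and lower numbers for stronger inhibition:
compound 1 `CCN(CC)S(=O)(=O)c1ccc(S(=O)(=O)N2CCC[C@@H](C(=O)NC3COC3)C2)cc1` gives 13800 nM
compound 2 `CCOC(=O)[C@@H]1CCCN(S(=O)(=O)c2ccc(S(=O)(=O)N3CCCCC3)cc2)C1` gives 3300 nM

Of these two, compound 2 holds the lower number, and the gap to compound 1 is beyond the usual scatter of this assay. Compound 3 `CCOC(=O)[C@@H]1CCCN(S(=O)(=O)c2ccc(S(=O)(=O)N(C)C)cc2)C1` differs from compound 2 in one place: dimethylamino in place of piperidin-1-yl on a sulfonyl sulfur. Among the compounds with values here, no measured pair shows a change of this kind, so the size of the step is uncertain; a small move toward a higher number, possibly within the scatter, is expected as a 1.7-fold higher number from compound 2 to compound 3 (0.22 log units; within the scatter). Compound 3 is therefore expected to give about 5500 nM, between 2000 nM and 16000 nM.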

Compound 3, half-maximal inhibitory concentration: 1000 nM
Compound 3: middle estimate off by 5.5-fold (0.74 log units), on the high side; the measured number lies below the stated range.
By their numbers in this assay, from the lowest: compound 3; then compound 2; then compound 1.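

At this position, on a sulfonyl sulfur whose other neighbour is an aromatic carbon, the ring of piperidin-1-yl is not needed to keep activity in this assay. Dimethylamino has fewer heavy atoms and no ring, yet the change gives a 3.3-fold lower number from compound 2 to compound 3 (0.52 log units; beyond the scatter), a modest gain in inhibition. Nothing available gives a reason for this gain.

This single step leaves open whether the number keeps falling with a plain amine or a methylamino group at the same place. It also leaves open how a morpholine ring would compare.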